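This account rests on a few compounds, and the source may have more. Where it says the series, first, only, none or still open, it means among the compounds named here.

Working notes on the series. In a functional assay on DU-145 cells (Homo sapiens) for inhibition, read by trypan blue exclusion, with a stated time of 96 h (a lower number here means a stronger inhibitor of growth, a higher number a weaker inhibitor of growth), compound 1 (`Cc1ccc(CS/C(=C/c2ccc(F)c(C)c2)C(=O)c2ccc(Cl)cc2)cc1`) gives 25000 nM and compound 3 (`O=C(/C(=C\c1ccc(Br)cc1)Sc1ccccc1Br)c1ccc(Br)cc1`) gives 1000 nM as measured numbers. Compound 2 (`Cc1ccc(S/C(=C/c2ccc(N(C)C)cc2)C(=O)c2ccc(Cl)cc2)cc1`) gives > 100000 nM in this assay and this is a limit of the assay, not a number. Compound 2 is the only one of the three reported as a limit, so it has no exact position in the series.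

Compound 4 (`COc1ccc(/C=C(/Sc2ccc(C)cc2)C(=O)c2ccc(Cl)cc2)cc1O`) follows from compound 2 by a single change, 3-hydroxy-4-methoxyphenyl in place of 4-(dimethylamino)phenyl on a double-bonded chain carbon bound to a double-bonded chain carbon in which 3-hydroxy-4-methoxyphenyl stands in place of 4-(dimethylamino)phenyl on a double-bonded chain carbon bound to a double-bonded chain carbon. Within the data shown here, no pair of measured compounds differs in one place only, so the series offers no direct precedent for this change. The expectation rests on the spread of the measured compounds, with compound 1 at 25000 nM and compound 3 at 1000 nM as the numeric guides. A move toward stronger inhibition of growth is expected, with the expected change being an at least 20-fold lower number from compound 2 to compound 4 (1.30 log units; beyond the scatter) and its size uncertain because the starting point is only a limit. For compound 4 the estimate is 5000 nM with an expected range from 800 nM to 30000 nM in this assay once tested.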

Compound 4, concentration for 50% growth inhibition: 1000 nM
For compound 4 the middle estimate is 5.0-fold (0.70 log units) above the measured one; low and high end bracket the measured number.
By their numbers in this assay, from the lowest: compounds 3 and 4 (each within the scatter of the next); then compound 1. At a limit, above all of these: compound 2.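

In this assay, among these compounds, the exchange of 4-(dimethylamino)phenyl for 3-hydroxy-4-methoxyphenyl on a double-bonded chain carbon bound to a double-bonded chain carbon gives an at least 100-fold lower number from compound 2 to compound 4 (2.00 log units; beyond the scatter) and is the first comparison at a single place, showing that this position alone can carry a large change in growth inhibition. The two groups match in their 9 heavy atoms and their six-membered aromatic ring of carbon only, while the entering group brings 1 hydrogen-bond donor and 2 hydrogen-bond acceptors against 0 and 1 for the leaving group, so the step follows the change in substituents rather than in group size. The step can be stated only as a bound because compound 2 stands at a limit of the assay: the limit of > 100000 nM in this assay, at which 1 of the 4 values shown sits.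

As far as these compounds go, whether the hydroxy or the methoxy carries the step stays open, as does how a primary amine or a carboxylic acid on the same phenyl would read. From the compounds shown here alone, compound 1 and compound 3 differ from compound 4 in more than one place, so the contribution of the other parts of the core also stays open.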